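Chloro for fluoro at two sites in an indolylmethanol series

The source may hold more compounds than are shown below. What is called first, only, known or untested is meant among the compounds shown, and "the series" means these compounds.

Compound 1 `OCc1cn(Cc2cccc(F)c2)c2ccccc12` gives 40 nM in a functional assay on NCI-H460 cells (Homo sapiens) for cytotoxicity, read by sulforhodamine B assay, with a stated time of 3 days; on this read-out higher numbers stand for weaker inhibition and lower numbers for stronger inhibition. Compound 2 `OCc1cn(Cc2cccc(Cl)c2)c2ccccc12` gives 19 nM in this assay; the change chloro in place of fluoro on an aromatic carbon made the step of a 2.1-fold lower number from compound 1 to compound 2 (0.32 log units; beyond the scatter), with the chloro sitting meta to a large group. Compound 3 `OCc1cn(Cc2ccc(Cl)cc2)c2ccc(F)cc12` gives 30 nM in this assay; how its core differs from that of compound 1 is not broken down here. Compound 4 `OCc1cn(Cc2ccc(Cl)cc2)c2ccc(Cl)cc12` is not yet measured. It differs from compound 3 by chloro in place of fluoro on an aromatic carbon, the same kind of change as from compound 1 to compound 2, but here the place is part of a fused or bridged system of two rings, meta to a fused ring and para to a fused ring. A step of similar size is expected, a 1.7-fold lower number from compound 3 to compound 4 (0.22 log units; within the scatter), resting on a 2.1-fold lower number from compound 1 to compound 2 (0.32 log units; beyond the scatter) alone. Compound 4 is therefore estimated at 18 nM, between 8 nM and 40 nM.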

Compound 4, half-maximal inhibitory concentration: 5750 nM
The estimate for compound 4 lay 320-fold (2.50 log units) below the measured number, and the stated range ends below it.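

In this assay, chloro in place of fluoro on an aromatic carbon gives a 190-fold higher number from compound 3 to compound 4 (2.28 log units; beyond the scatter), so the step seen on one core cannot be carried to the other in this series: the same change on two cores in this assay, a 2.1-fold lower number (0.32 log units; beyond the scatter) from compound 1 to compound 2 and a 190-fold higher number (2.28 log units; beyond the scatter) from compound 3 to compound 4, 400-fold (2.61 log units) apart, beyond the scatter of two such steps

The two steps lie at different places on different cores, with one pair of compounds for each. They show that the outcome of the change depends on its setting, but not which difference between the two cores decides it.

As far as these compounds go, it remains open whether the large rise belongs to chloro at this place alone or to its pairing with the second chloro in compound 4. Also open, from the compounds shown here alone, is how a methoxy group or a nitrile would fare at the same place.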